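From 3-nitrophenyl to 3-chlorophenyl in the series

The source may hold more compounds than are shown below. What is called first, only, known or untested is meant among the compounds shown, and "the series" means these compounds.

For the measured compounds named here, in a functional assay on U-937 cells (Homo sapiens) for antiproliferative activity, read by CCK-8 assay, with a stated time of 72 h (a lower number here means a stronger inhibitor, a higher number a weaker inhibitor), compound 3 `Cc1cc(Nc2cc(N3CCN(C)CC3)nc(Nc3cccc([N+](=O)[O-])c3)n2)n[nH]1` gives 25.2 nM, the lowest of the three numbers so far. Compound 1 `Cc1cc(Nc2cc(N3CCN(C)CC3)nc(Nc3ccc(S(N)(=O)=O)cc3)n2)n[nH]1` gives 100 nM and compound 2 `COc1cccc(Nc2nc(Nc3cc(C)[nH]n3)cc(N3CCN(C)CC3)n2)c1` gives 126 nM. These two sit within the scatter of each other: a 1.3-fold higher number from compound 1 to compound 2 (0.10 log units; within the scatter). Two modest steps lie beyond the scatter: a 4.0-fold lower number from compound 1 to compound 3 (0.60 log units; beyond the scatter) and a 5.0-fold lower number from compound 2 to compound 3 (0.70 log units; beyond the scatter).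

Compound 4 `Cc1cc(Nc2cc(N3CCN(C)CC3)nc(Nc3cccc(Cl)c3)n2)n[nH]1` carries chloro in place of nitro on an aromatic carbon, meta to a large group: chloro in place of nitro on an aromatic carbon. The step that bears most directly on this change is a 5.0-fold lower number from compound 2 to compound 3 (0.70 log units; beyond the scatter), since it also exchanges the group on that aromatic carbon, and it shows that such an exchange can move the number in this assay beyond the scatter. The step to compound 3 from compound 1 is of similar size but changes the group's place as well. Going by the values given here, no measured compound carries chloro, so the size of the step remains uncertain. Nitro holds the lowest number so far, which suggests a move upward, probably smaller than the gap to methoxy. The expected step is a 2.0-fold higher number from compound 3 to compound 4 (0.30 log units; within the scatter). Compound 4 is estimated at 50 nM, with an expected range of 18 nM to 140 nM.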

Compound 4, half-maximal inhibitory concentration: 21.7 nM
For compound 4 the middle estimate is 2.3-fold (0.36 log units) above the measured one; the measured number falls inside the stated range.
By their numbers in this assay, from the lowest: compounds 4 and 3 (each within the scatter of the next); then compounds 1 and 2 (each within the scatter of the next).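

In this assay, replacing nitro with chloro on this aromatic carbon, meta to a large group, does not separate the two compounds (a 1.2-fold lower number from compound 3 to compound 4 (0.06 log units; within the scatter)), so the low number is not confined to nitro, even though chloro has 1 heavy atom and 0 hydrogen-bond acceptors against 3 heavy atoms and 2 hydrogen-bond acceptors for nitro. The exchange of methoxy for chloro at the same carbon lies beyond the scatter (a 5.8-fold lower number from compound 2 to compound 4 (0.76 log units; beyond the scatter)), as does the replacement of 4-sulfamoylphenyl with 3-chlorophenyl (a 4.6-fold lower number from compound 1 to compound 4 (0.66 log units; beyond the scatter)), although the latter changes the group and its place together and so cannot be assigned to either alone. The series carries no measurement that bears on why nitro and chloro read alike here, or why methoxy stands apart from both.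

Going by these compounds, it remains open whether an amine or a carboxylic acid on this carbon would stay with nitro and chloro or read nearer to methoxy. Also open, on these data alone, is what chloro would give in the place held by the sulfamoyl group in compound 1, which would separate the effect of place from that of the group.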